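The source may hold more compounds than are shown below. What is called first, only, known or untested is meant among the compounds shown, and "the series" means these compounds.

Working notes on the series: in an ADME assay for permeability (a higher number here means that the compound crosses the layer faster, a lower number that the compound crosses the layer more slowly), compound 1 (`CNC(=O)c1cc(C(=O)N[C@H]2CC[C@H](O)CC2)c([C@@H](C)c2cccc(Cl)c2)o1`) gives 150 nm/s and compound 2 (`CNC(=O)c1cc(C(=O)N[C@H]2[C@@H]3C[C@@H](O)C[C@@H]32)c([C@@H](C)c2ccccc2)o1`) gives 45 nm/s, the lower of the two numbers, with a gap beyond the scatter. Compound 3 (`CNC(=O)c1cc(C(=O)N[C@H]2CC[C@H](O)CC2)c([C@@H](C)c2ccccc2)o1`) has not yet been measured. On the amide-type nitrogen, compound 3 differs from compound 2 by a group of 7 heavy atoms (6 carbon, 1 oxygen; one six-membered non-aromatic ring of carbon only) in place of a group of 7 heavy atoms (6 carbon, 1 oxygen; one three-membered non-aromatic ring of carbon only, one five-membered non-aromatic ring of carbon only), on an amide-type nitrogen. Among the measured compounds shown here, no measured step isolates this change, so the guide is weak. The expected change, a 1.6-fold higher number from compound 2 to compound 3 (0.19 log units; within the scatter), is a modest rise near the scatter. For compound 3 the estimated value is 70 nm/s, with an expected range of 35 nm/s to 140 nm/s.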

Compound 3, apparent permeability in the ADME assay: 42 nm/s
Estimate against measurement, compound 3: 1.7-fold (0.22 log units) above, and the stated range covers the measured number.
By their numbers in the ADME assay, from the lowest: compounds 3 and 2 (each within the scatter of the next); then compound 1.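

On the amide-type nitrogen, 4-hydroxycyclohexyl in place of the fused-ring group gives in the ADME assay a 1.1-fold lower number from compound 2 to compound 3 (0.03 log units; within the scatter), and in a physicochemical assay for lipophilicity (on this read-out lower numbers stand for lower lipophilicity and higher numbers for higher lipophilicity), where compound 2 gives 2.8 and compound 3 gives 2.8, the same change gives no change at the digits printed from compound 2 to compound 3 (within the scatter), so neither read-out separates these two groups. In the ADME assay, hydrogen in place of chloro on an aromatic carbon gives a 3.6-fold lower number from compound 1 to compound 3 (0.55 log units; beyond the scatter), the only step shown that lies beyond the scatter. Nothing measured accounts for either step.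

Still open, from the compounds shown here alone, is whether bromo or methoxy on that aromatic carbon, or an amine in place of 4-hydroxycyclohexyl on the amide-type nitrogen, would follow these steps.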